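The compounds below may be only part of what the source reports. "The series", "measured", "known", "first", "only" and "open" are said of these compounds alone.

Of the compounds shown here, three sharing one core have been measured in an ADME assay on MT2 cells (Homo sapiens) for cytotoxicity; on this read-out lower numbers stand for higher toxicity in this test and higher numbers for lower toxicity in this test. Compound 1 `CC(C)=CCOc1cc(Nc2ncnc(Cl)n2)ccc1Cl` gives 45000 nM, compound 2 `CC(C)=CCOc1cc(Nc2ncnc(N)n2)ccc1Cl` gives 48000 nM, and compound 3 `COc1ccnc(Nc2ccc(Cl)c(OCC=C(C)C)c2)n1` gives 9000 nM. Compound 3 stands at the lowest of the three numbers, which on this read-out means the strongest toxicity; its nearest neighbour is compound 1, and the gap to it, as to compound 2, lies beyond the scatter. Among the measured compounds shown here, the only measured step between close neighbours, a 1.1-fold higher number from compound 1 to compound 2 (0.03 log units; within the scatter), shows that putting amino in place of chloro on an aromatic carbon left the number essentially where it was.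

Compound 4 `CC(C)=CCOc1cc(Nc2nccc(N)n2)ccc1Cl` is to be measured in this assay. It differs from compound 3 by amino in place of methoxy on an aromatic carbon. For the measured compounds named here, no measured pair shows this exact exchange; the one step available, from compound 1 to compound 2, concerns a different exchange on a different core and was flat. With nothing pointing to a large movement, a small step is expected, a 1.7-fold higher number from compound 3 to compound 4 (0.22 log units; within the scatter). Compound 4 is therefore estimated at 15000 nM, within a range from 5000 nM to 45000 nM, leaning toward a higher number because compound 2, which also carries an amino, sits at 48000 nM.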

Compound 4, half-maximal cytotoxic concentration: 500 nM
Compound 4: the middle estimate sits 30-fold (1.48 log units) above what was measured; the measured number lies below the stated range.
By their numbers in this assay, from the lowest: compound 4; then compound 3; then compounds 1 and 2 (each within the scatter of the next).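

In this assay the exchange of methoxy for amino, on an aromatic carbon next to the ring nitrogen, gives an 18-fold lower number from compound 3 to compound 4 (1.26 log units; beyond the scatter) and so shows that this one place can move the number a long way, something the flat amino-for-chloro step on the other core gave no sign of. The amino group does not do this wherever it stands: compound 2 also carries one, inside its 4-amino-1,3,5-triazin-2-yl group, yet putting 4-aminopyrimidin-2-yl in that group's place gives a 96-fold lower number from compound 2 to compound 4 (1.98 log units; beyond the scatter) and putting it in place of the 4-chloro-1,3,5-triazin-2-yl group gives a 90-fold lower number from compound 1 to compound 4 (1.95 log units; beyond the scatter). Among these four compounds, then, the much higher toxicity in this test appears only where amino sits on the 4-aminopyrimidin-2-yl group of compound 4, so the amino and the group carrying it have to be read together.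

Nothing at hand accounts for the size of this drop. Still open, going by these compounds, is whether methylamino, dimethylamino or hydroxyl at this same place would keep the number this low, or whether the plain amino is needed.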